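This account rests on a few compounds, and the source may have more. Where it says the series, first, only, none or still open, it means among the compounds named here.

Measured in an ADME assay on U2OS cells (Homo sapiens) for cytotoxicity; a higher number here means that more compound is tolerated, a lower number that less compound is tolerated:
Compound 1, `CCCCCCc1ccc(C(=O)N/N=C/c2ccc([N+](=O)[O-])o2)cc1`, gives > 200000 nM.
Compound 2, `O=C(N/N=C/c1ccc([N+](=O)[O-])o1)c1ccc2ccccc2c1`, gives 64200 nM.
Compound 3, `N#Cc1ccc(C(=O)N/N=C/c2ccc([N+](=O)[O-])o2)cc1`, gives 21400 nM.

Compound 1 stands at the limit of > 200000 nM in this assay, at which 1 of the 3 values shown sits; its value is a limit of the assay and not a measured number. Among the measured compounds shown here, compound 2 and compound 3, by contrast, each return a number, and the only one-place step among the three, an at least 9.3-fold lower number from compound 1 to compound 3 (0.97 log units; beyond the scatter), goes toward less tolerated compound when cyano replaces hexyl on the aromatic carbon.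

The next compound, compound 4, `CCCCCCCCc1ccc(C(=O)N/N=C/c2ccc([N+](=O)[O-])o2)cc1`, differs from compound 1 by ethyl in place of hydrogen on a saturated chain carbon, six bonds along the chain from an aromatic carbon. For the measured compounds named here, no measured step concerns a longer chain on this position; the step from compound 1 to compound 3 moves in the opposite structural direction, exchanging the chain for a small polar group, so it offers no direct guide. With compound 1 already at the limit, the expectation for compound 4 is no step beyond the scatter in this assay, most likely a value again reported only as a limit, with a modest chance that the longer chain yields a measurable number somewhat below it. Compound 4 is therefore estimated at 200000 nM, within 60000 nM to 500000 nM, an expected step of a number no higher from compound 1 to compound 4 (the limit leaves the size open).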

Compound 4, half-maximal cytotoxic concentration: > 200000 nM
Compound 4: no number, only a limit; the forecaster's own chance of this, stated with the estimate: 65%; the middle value sits exactly at the limit.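

In this assay compound 4 gives > 200000 nM, which is a limit of the assay and not a number. Compound 4 thus sits at the same limit as compound 1, so the step between them cannot be read, and ethyl in place of hydrogen on a saturated chain carbon, six bonds along the chain from an aromatic carbon, gives no readable change in this assay: the limit of > 200000 nM in this assay, at which 2 of the 4 values shown sit. What can be read is an at least 9.3-fold higher number from compound 3 to compound 4 (0.97 log units; beyond the scatter), with octyl in place of cyano on an aromatic carbon, so that a second chain on this aromatic carbon, after the hexyl of compound 1, stands clearly apart from the cyano of compound 3.

The compounds shown leave open whether shorter chains such as methyl or propyl would give a measurable number between that of compound 3 and the limit, or whether a chain carrying an amine or a carboxylic acid in place of octyl would do so. They also leave open how far compound 1 and compound 4 lie beyond the limit, and so whether the length of the chain matters at all on this position.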